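The compounds below may be only part of what the source reports. "The series", "measured", "known", "first", "only" and "open" are said of these compounds alone.

The measured compounds:
compound 1, `CCCCN(c1nc2c(NC(C)=O)cccc2o1)[C@H](C)c1ccc(-c2ccccc2-c2nnn[nH]2)cc1`, gives 22 nM in a functional assay on CAL1 cells for inhibition of chemerin-like receptor 1 (Homo sapiens), with a stated time of 45 min; a higher number here means a weaker inhibitor, a lower number a stronger inhibitor;
compound 2, `C[C@H](c1ccc(-c2cc(F)ccc2-c2nc(=O)o[nH]2)cc1)N(CC1CC1)c1nc2c(C(=O)O)cccc2o1`, gives 2.3 nM in this assay;
compound 3, `CCCCN(c1nc2c(C(=O)N(C)C)cccc2o1)[C@H](C)c1ccc(-c2ccccc2-c2nnn[nH]2)cc1`, gives 13 nM in this assay.

Compound 3 stands second highest of these three numbers. Within the data shown here, its nearest neighbour is compound 1, and the single measured step between the two, a 1.7-fold lower number from compound 1 to compound 3 (0.23 log units; within the scatter), lies within the scatter. Compound 2 shows the lowest number of the three, but it differs from compound 3 in more than one place, so its value alone says nothing about any single change.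

Compound 4, `CCCCN(c1nc2c(C(=O)NS(C)(=O)=O)cccc2o1)[C@H](C)c1ccc(-c2ccccc2-c2nnn[nH]2)cc1`, differs from compound 3 in one place: methanesulfonamido in place of dimethylamino on a carbonyl carbon. Among the measured compounds shown here, no measured step involves this change. For the measured compounds named here, the only step available, a 1.7-fold lower number from compound 1 to compound 3 (0.23 log units; within the scatter), concerns a different group on an aromatic carbon and was within the scatter, so it offers no guide to the size or direction of the step from dimethylcarbamoyl to (methylsulfonyl)carbamoyl. With nothing in the data pointing to a large move, a step in this assay that stays near the scatter is the most defensible expectation. Compound 4 is therefore estimated at 9 nM, with a range from 2.5 nM to 35 nM. This estimate means an expected step of a 1.4-fold lower number from compound 3 to compound 4 (0.16 log units; within the scatter), which may well fall within the scatter.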

Compound 4, half-maximal inhibitory concentration: 14 nM
The estimate for compound 4 lay 1.6-fold (0.19 log units) below the measured number, and the stated range covers the measured number.
By their numbers in this assay, from the lowest: compound 2; then compounds 3, 4 and 1 (each within the scatter of the next).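

In this assay, methanesulfonamido in place of dimethylamino on a carbonyl carbon gives a 1.1-fold higher number from compound 3 to compound 4 (0.03 log units; within the scatter) and so stays within the scatter, even though the entering group has more heavy atoms and brings a hydrogen-bond donor and acceptors that dimethylamino lacks. The step of (methylsulfonyl)carbamoyl in place of acetamido on an aromatic carbon, a 1.6-fold lower number from compound 1 to compound 4 (0.20 log units; within the scatter), also lies within the scatter, so acetamido, dimethylcarbamoyl and (methylsulfonyl)carbamoyl all stand within the scatter of one another at this place on the shared core. Nothing measured here offers an explanation for this result.

From the compounds shown here alone, whether a carboxylic acid on this aromatic carbon would carry the core of compound 3 beyond the scatter stays open: compound 2 has such a group and gives 2.3 nM in this assay, but it differs from compound 3 in more than one place. Also open, going by these compounds, is what a simple primary amide, or a phenylsulfonyl group in place of the methylsulfonyl of compound 4, would give at this position.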